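Halogen steps and the fluoro entry

The compounds below may be only part of what the source reports. "The series", "measured", "known", "first", "only" and "open" are said of these compounds alone.

In a functional assay on MCF7 cells (Homo sapiens) for cytotoxicity, read by MTT assay, with a stated time of 48 h (on this read-out lower numbers stand for stronger inhibition and higher numbers for weaker inhibition), compound 1 (`C/C(=N\NC(=S)Nc1ccc(Cl)cc1)c1ccccn1`) gives 8.49 nM, compound 2 (`C/C(=N\NC(=S)Nc1ccc(I)cc1)c1ccccn1`) gives 6.61 nM and compound 3 (`C/C(=N\NC(=S)Nc1ccccc1)c1ccccn1`) gives 0.18 nM, the lowest number of the three. Compound 4 (`C/C(=N\NC(=S)Nc1ccc(F)cc1)c1ccccn1`) has fluoro in place of hydrogen on an aromatic carbon, para to a large group: fluoro in place of hydrogen on an aromatic carbon.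

Among the compounds with values here, three measured steps bear on this change. Iodo in place of chloro stays within the scatter, a 1.3-fold lower number from compound 1 to compound 2 (0.11 log units; within the scatter). Hydrogen in place of either halogen gives large steps, a 47-fold lower number from compound 1 to compound 3 (1.67 log units; beyond the scatter) and a 37-fold lower number from compound 2 to compound 3 (1.56 log units; beyond the scatter), so a halogen added to compound 3 is expected to raise the number. Only chloro and iodo have been measured, so the fluoro step may fall short of these two. A rise beyond the scatter is therefore expected in this assay. The expected step is a 14-fold higher number from compound 3 to compound 4 (1.14 log units; beyond the scatter). Compound 4 is estimated at 2.5 nM, with an expected range of 0.4 nM to 11 nM.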

Compound 4, half-maximal inhibitory concentration: 1.2 nM
The estimate for compound 4 lay 2.1-fold (0.32 log units) above the measured number, and the stated range covers the measured number.
By their numbers in this assay, from the lowest: compound 3; then compound 4; then compounds 2 and 1 (each within the scatter of the next).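

In this assay the rise seen on putting a halogen on compound 3 holds for fluoro as well, with a 6.7-fold higher number from compound 3 to compound 4 (0.82 log units; beyond the scatter) as a modest step, whereas the chloro and iodo steps are large. The halogens at this position therefore do not act as one group: a 7.1-fold lower number from compound 1 to compound 4 (0.85 log units; beyond the scatter) and a 5.5-fold lower number from compound 2 to compound 4 (0.74 log units; beyond the scatter) are both beyond the scatter, while chloro and iodo stay within the scatter of each other. Across these four compounds the position thus gives three levels, with hydrogen lowest, fluoro in the middle and chloro and iodo together highest.

Going by these compounds, whether any group other than a halogen on this carbon, such as methoxy, an amine or a carboxylic acid, would keep the number near that of hydrogen remains open. Nothing at hand explains this order.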